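Notes on the acetoxy to (butylcarbonyl)oxy change

The compounds below may be only part of what the source reports. "The series", "measured", "known", "first", "only" and "open" are said of these compounds alone.

In a functional assay on SK-MES-1 cells (Homo sapiens) for antiproliferative activity (a higher number here means a weaker inhibitor, a lower number a stronger inhibitor), compound 1 (`Nc1nc(=O)n([C@H]2C=C[C@@H](CO)O2)cc1I`) gives > 100000 nM as a limit of the assay. For the measured compounds named here, compound 2 (`O=c1[nH]c(=O)n([C@@H]2C=C[C@H](CO)O2)cc1F`) gives 4600 nM as the only actual number. Compound 3 (`CC(=O)OC[C@@H]1C=C[C@H](n2cc(F)c(N)nc2=O)O1`) gives > 100000 nM as a limit, and it has no number of its own. Compared with compound 3, compound 4 (`CCCCC(=O)OC[C@@H]1C=C[C@H](n2cc(F)c(N)nc2=O)O1`) shows propyl in place of hydrogen on a saturated chain carbon bound to a carbonyl carbon as its change: propyl in place of hydrogen on a saturated chain carbon bound to a carbonyl carbon, which also reads as acetoxy to (butylcarbonyl)oxy. No measured step sizes this change in this assay. A small shift toward a lower number is expected, possibly none beyond the scatter. The expected step is an at least 1.2-fold lower number from compound 3 to compound 4 (0.09 log units; that floor lies within the scatter) as an estimate only. For compound 4 the estimated value is 80000 nM with an expected range of 15000 nM to 150000 nM in this assay.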

Compound 4, half-maximal inhibitory concentration: > 100000 nM
Compound 4: a limit, no number (the forecaster's own chance of this, stated with the estimate: 60%); middle value at least 1.2-fold (0.09 log units) from the limit.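

No step can be read from compound 3 to compound 4, because both values are limits and not numbers: the limit of > 100000 nM in this assay, at which 3 of the 4 values shown sit.

The compounds shown leave open whether acetoxy to (butylcarbonyl)oxy shifts the antiproliferative read-out at all, and in which direction.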